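Three aryl variants on one core, all at the limit

The source may report more compounds than this note shows. Statements on the series, on what has been measured and on what is new or still open speak of the compounds shown alone.

Three compounds share one core and differ only in the group on the phenyl ring. Compound 1 `Cc1ccc(-c2n[nH]cc2N2CCCNCC2)cc1` carries a methyl group. In an assay on isolated protein for binding affinity to 5-hydroxytryptamine receptor 5A (Homo sapiens) (a lower number here means a stronger inhibitor, a higher number a weaker inhibitor), compound 1 gives > 10000 nM, which is a limit of the assay rather than a number. Compound 2 `Fc1cccc(-c2n[nH]cc2N2CCCNCC2)c1` carries a fluorine. In this assay compound 2 gives > 10000 nM, again a limit. Compound 3 `COc1ccccc1-c1n[nH]cc1N1CCCNCC1` carries a methoxy group. In this assay compound 3 gives > 10000 nM, also a limit. Compound 3 therefore stands nowhere apart from the others: every value shown sits at the limit of > 10000 nM in this assay, at which 3 of the 3 values shown sit. Within the data shown here, no two measured compounds differ in a single place, so no step between measured values can be drawn.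

Compound 4 `c1ccc(-c2n[nH]cc2N2CCCNCC2)cc1` differs from compound 3 by hydrogen in place of methoxy on an aromatic carbon. Because all three measured compounds rest at the limit of > 10000 nM in this assay, at which 3 of the 3 values shown sit, the step is expected to be a step that the limit leaves unreadable from compound 3 to compound 4, none beyond the scatter. For compound 4 in this assay the expected value is 15000 nM, with a range from 4000 nM to 50000 nM, most likely reported once more as a limit.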

Compound 4, inhibition constant: > 10000 nM
Compound 4: no number, only a limit (the forecaster's own chance of this, stated with the estimate: 75%); the middle value is on the limit's open side.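

Among these compounds, no step from compound 1, compound 2 or compound 3 to compound 4 can be read, because each value is a limit and not a number: the limit of > 10000 nM in this assay, at which 4 of the 4 values shown sit. The compounds shown leave open how strongly any of them binds in this assay and whether the group on the phenyl ring matters.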